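The compounds below may be only part of what the source reports. "The series", "measured", "known", "first", "only" and "open" are said of these compounds alone.

Measured compounds:
- compound 1, `O=C(Nc1ccc(Oc2ccnc3[nH]ccc23)cc1)c1cn(-c2ccc(Cl)cc2)c2ccccc2c1=O`: 1590 nM
- compound 2, `O=C(Nc1ccc(Oc2ccnc3[nH]ccc23)cc1)c1cn(-c2ccc(Br)cc2)c2ccccc2c1=O`: 610 nM
- compound 3, `O=C(Nc1ccc(Oc2ccnc3[nH]ccc23)c(F)c1)c1cn(-c2ccc(Cl)cc2)c2ccccc2c1=O`: "not determined" (no result reported)

In a functional assay on MCF7 cells (Homo sapiens) for inhibition, read by MTT assay, with a stated time of 72 h (on this read-out higher numbers stand for weaker inhibition and lower numbers for stronger inhibition), compound 1 gives 1590 nM and compound 2 gives 610 nM. The two differ by bromo in place of chloro on an aromatic carbon, which produced a 2.6-fold lower number from compound 1 to compound 2 (0.42 log units; beyond the scatter). Compound 3 carries the core of compound 1 changed by fluoro in place of hydrogen on an aromatic carbon; for compound 3 this assay gave "not determined" (no result reported), so the effect of that change on the core is not known from the data. Compound 4, `O=C(Nc1ccc(Oc2ccnc3[nH]ccc23)c(F)c1)c1cn(-c2ccc(Br)cc2)c2ccccc2c1=O`, stands to compound 3 as compound 2 stands to compound 1: the change is bromo in place of chloro on an aromatic carbon, and its place line reads the same word for word as the earlier one, so it is the same change on the fluoro-bearing core. Going by the values given here, the one measured pair shows a 2.6-fold lower number from compound 1 to compound 2 (0.42 log units; beyond the scatter); a change of about that size in this assay is expected when going on to compound 4, resting on that single measured pair alone, with wide uncertainty, since compound 3 has no number to anchor it. Compound 4 is expected to give 700 nM, within a range from 200 nM to 2500 nM.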

Compound 4, half-maximal inhibitory concentration: 650 nM
The estimate for compound 4 lay 1.1-fold (0.03 log units) above the measured number, and the stated range covers the measured number.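

In this assay, fluoro in place of hydrogen on an aromatic carbon gives a 1.1-fold higher number from compound 2 to compound 4 (0.03 log units; within the scatter), so compound 2 and compound 4 stand level and this change shows no measurable effect on the core carrying the 4-bromophenyl group. Going by these compounds alone, this does not show how the change from 4-chlorophenyl to 4-bromophenyl carries onto the fluoro-bearing core: compound 3 has no number, the step from it to compound 4 cannot be read, and a 2.6-fold lower number from compound 1 to compound 2 (0.42 log units; beyond the scatter) remains the only reading of that change. No measurement at hand accounts for either step.

The compounds shown leave open whether fluoro in place of hydrogen would also leave the read-out level on the core carrying the 4-chlorophenyl group. They also leave open how groups other than the two halogens, such as methoxy, nitrile or an amine, would read at the same place, para to a large group.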